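A few compounds are considered here, and "the series" means these few. Any claim that something is new, unique, unknown or untested is made for them only; others in the source may bear on it.

Of the compounds shown here, three sharing one core have been tested in a functional assay on CHO-K1 cells for antagonist activity at transient receptor potential cation channel subfamily V member 1 (Homo sapiens), read by FLIPR; a lower number here means a stronger inhibitor, a higher number a weaker inhibitor. Compound 1 `CC(C(=O)NCc1ccc(C(F)(F)F)nc1Nc1ccc(F)cc1)c1ccc(NS(C)(=O)=O)c(F)c1` gives 39.2 nM in this assay. Compound 2 `CC(C(=O)NCc1ccc(C(F)(F)F)nc1N1CC=CCC1)c1ccc(NS(C)(=O)=O)c(F)c1` gives 0.3 nM, and compound 3 `CC(C(=O)NCc1ccc(C(F)(F)F)nc1N1CCN(C)CC1)c1ccc(NS(C)(=O)=O)c(F)c1` gives 146 nM, the highest number of the three and so the weakest inhibitor. The measured steps are a 130-fold lower number from compound 1 to compound 2 (2.12 log units; beyond the scatter), a 3.7-fold higher number from compound 1 to compound 3 (0.57 log units; beyond the scatter) and a 490-fold higher number from compound 2 to compound 3 (2.69 log units; beyond the scatter); each swaps the whole group that sits on the aromatic carbon of the core. Compound 4 `COc1ccc(N2CCN(c3nc(C(F)(F)F)ccc3CNC(=O)C(C)c3ccc(NS(C)(=O)=O)c(F)c3)CC2)cc1` keeps the six-membered non-aromatic ring with two nitrogens of compound 3 and alters only the group on the amine nitrogen in that ring: 4-methoxyphenyl in place of methyl on an amine nitrogen in a ring. Within the data shown here, no measured step touches this position, so none bears directly on the change; the only hint is that compound 1, which carries an aromatic ring in this part of the molecule, gives a lower number than compound 3, as a 3.7-fold higher number from compound 1 to compound 3 (0.57 log units; beyond the scatter) shows in reverse. Compound 4 is therefore expected to stay close to compound 3, with a step of a 1.8-fold lower number from compound 3 to compound 4 (0.26 log units; within the scatter) expected, leaning slightly toward stronger inhibition. The estimate for compound 4 in this assay is 80 nM, expected to fall between 15 nM and 400 nM.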

Compound 4, inhibition constant: 2.5 nM
Compound 4: middle estimate off by 32-fold (1.51 log units), on the high side; measured number below the stated range.
By their numbers in this assay, from the lowest: compound 2; then compound 4; then compound 1; then compound 3.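

With the ring containing two nitrogens kept, replacing only the group on its amine nitrogen gives a 58-fold lower number from compound 3 to compound 4 (1.77 log units; beyond the scatter) in this assay. Among these compounds, this position therefore strongly affects the reading, something the earlier steps could not show, since each of them swapped the whole group on the aromatic carbon of the core. The weak number of compound 3 thus cannot be assigned to the ring alone, since it depends on the ring carrying methyl rather than 4-methoxyphenyl, and no measurement available here explains the size of this change.

The compounds shown leave open whether the aromatic ring alone accounts for the step or whether its methoxy group also contributes, a question that an unsubstituted phenyl on the same nitrogen would address. They also leave open how a benzyl group or a longer carbon chain at this position would read.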